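Methyl Ester to Ethyl Ester on the Ureidomethyl Amine

This account rests on a few compounds, and the source may have more. Where it says the series, first, only, none or still open, it means among the compounds named here.

Compound 1 `COC(=O)c1ccccc1OCC(O)CNC(C)C` was tested in a functional assay with Cavia porcellus as the target (on this read-out higher numbers stand for weaker binding and lower numbers for tighter binding), and gives 5.01 nM. Compound 2 `COC(=O)c1ccccc1OCC(O)CNC(C)(C)C` gives 1.59 nM in this assay. Compound 3 `COC(=O)c1ccccc1OCC(O)CNC(C)(C)CNC(N)=O` gives 1.26 nM in this assay. Compound 4 `CCOC(=O)c1ccccc1OCC(O)CNC(C)(C)CNC(N)=O` has not yet been measured in this assay.

The change methyl in place of hydrogen on a saturated chain carbon bound to an amine nitrogen and two saturated chain carbons gave a 3.2-fold lower number from compound 1 to compound 2 (0.50 log units; beyond the scatter). The cores of compound 1 and compound 3 differ by ureidomethyl in place of hydrogen on a saturated chain carbon bound to an amine nitrogen and two saturated chain carbons, which gave a 4.0-fold lower number from compound 1 to compound 3 (0.60 log units; beyond the scatter), while the step of a 1.3-fold lower number from compound 2 to compound 3 (0.10 log units; within the scatter) separates the two larger amines. Compound 4 carries the same kind of change relative to compound 3 as compound 2 does relative to compound 1, namely (methyl in place of hydrogen on a saturated chain carbon bound to an oxygen next to a carbonyl group), but not the same change: in compound 2 the methyl enters on a saturated chain carbon bound to an amine nitrogen and two saturated chain carbons, whereas in compound 4 it enters on a saturated chain carbon bound to an oxygen next to a carbonyl group. Within the data shown here, no measured pair shows a methyl added at that second place, so the earlier step is only a loose guide. The step from compound 3 to compound 4 is expected to be a 1.0-fold higher number from compound 3 to compound 4 (0.01 log units; within the scatter), smaller than the earlier one, because a 3.2-fold lower number from compound 1 to compound 2 (0.50 log units; beyond the scatter) was made at a different place. Compound 4 is estimated at 1.3 nM, within an expected range from 0.5 nM to 3.5 nM.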

Compound 4, dissociation constant: 0.126 nM
Compound 4: middle estimate off by 10-fold (1.01 log units), on the high side; the measured number lies below the stated range.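

In this assay, the change from methoxycarbonyl to ethoxycarbonyl gave a 10-fold lower number from compound 3 to compound 4 (1.00 log units; beyond the scatter). Set beside the earlier methyl step, this one differs in size: the same change on two cores in this assay, a 3.2-fold lower number (0.50 log units; beyond the scatter) from compound 1 to compound 2 and a 10-fold lower number (1.00 log units; beyond the scatter) from compound 3 to compound 4, 3.2-fold (0.50 log units) apart, beyond the scatter of two such steps This shows that, in this series, a methyl in place of hydrogen does not carry a single size of step from one core to another, but it does not show that the core sets the gap: the two methyls also enter at different places, one on a saturated chain carbon bound to an amine nitrogen and two saturated chain carbons, the other on a saturated chain carbon bound to an oxygen next to a carbonyl group.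

The compounds shown leave open whether methoxycarbonyl to ethoxycarbonyl gives a step of like size on the core of compound 1 or compound 2, which would separate the place of the change from the core. They also leave open how a longer chain on the ester, such as propyl, or a carboxylic acid in its stead would read in this assay.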